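This account rests on a few compounds, and the source may have more. Where it says the series, first, only, none or still open, it means among the compounds named here.

Measured compounds:
compound 1, `O=C(/C=C/c1ccc(O)c(O)c1)N1CCN(S(=O)(=O)c2cccc3cnccc23)CC1`: 790 nM
compound 2, `O=C(CCc1ccc(O)c(O)c1)N1CCN(S(=O)(=O)c2cccc3cnccc23)CC1`: 320 nM

The read-out throughout is an assay on isolated protein for inhibition of Rho-associated protein kinase 2 (Homo sapiens), read by 33P incorporation, with a stated time of 30 min, in the presence of a further agent that is not named here; on this read-out higher numbers stand for weaker inhibition and lower numbers for stronger inhibition. Within the data shown here, compound 2, with 320 nM, has the lowest of the two numbers; its nearest neighbour is compound 1, and the only measured step, a 2.5-fold lower number from compound 1 to compound 2 (0.39 log units; beyond the scatter), is a modest one that concerns the link to the carbonyl carbon and nothing on the ring.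

Compound 3, `COc1cc(CCC(=O)N2CCN(S(=O)(=O)c3cccc4cnccc34)CC2)ccc1O`, is not yet measured. It differs from compound 2 by methyl in place of hydrogen on an oxygen on an aromatic ring.

Among the measured compounds shown here, no measured step touches either oxygen on the aromatic ring, so the step from compound 1 to compound 2 does not bear on this change, and the two values give no guide to it beyond setting where compound 2 stands. With nothing to lean on, the number for compound 3 is expected to stay close to that of compound 2, with at most a small step in either direction, a 1.6-fold higher number from compound 2 to compound 3 (0.19 log units; within the scatter), possibly within the scatter. Compound 3 is therefore estimated at 500 nM, with a range from 180 nM to 1400 nM.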

Compound 3, half-maximal inhibitory concentration: > 10000 nM
Compound 3 ended at the assay's limit; the forecaster's own chance of this, stated with the estimate: 3%; middle value at least 20-fold (1.30 log units) away from the limit.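

Until now, only the link to the carbonyl carbon had been changed, and that step, a 2.5-fold lower number from compound 1 to compound 2 (0.39 log units; beyond the scatter), was modest; the aromatic ring had stayed the same. Going from 3,4-dihydroxyphenyl to 4-hydroxy-3-methoxyphenyl is the first change on the ring, and it gives a large step, an at least 31-fold higher number from compound 2 to compound 3 (1.49 log units; beyond the scatter), so this oxygen on the aromatic ring proves far less tolerant of change than the link, at least in this pair, where a single methyl in place of hydrogen is all that differs. In this assay compound 3 gives > 10000 nM, which is a limit of the assay and not a number: the limit of > 10000 nM in this assay, at which 1 of the 3 values shown sits.

The compounds shown leave open whether methyl on the other oxygen on the aromatic ring, as in a 3-hydroxy-4-methoxyphenyl group, would give a step of the same kind. They also do not tell whether the loss follows from the hydrogen leaving or from the methyl entering, a question that an amine or a fluorine in place of the hydroxy, or an ethyl on the same oxygen, would bear on.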